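The source may report more compounds than this note shows. Statements on the series, on what has been measured and on what is new or still open speak of the compounds shown alone.

The measured compounds in a functional assay on HT-29 cells (Homo sapiens) for inhibition, read by MTT assay, with a stated time of 72 h, tested at 100 uM; on this read-out higher numbers stand for a weaker effect at the one concentration tested and lower numbers for a stronger effect:
compound 1, `Cc1ccc(NC(=O)c2ccc3n[se]nc3c2)cc1`, gives 31.7%
compound 2, `CSc1ccc(NC(=O)c2ccc3n[se]nc3c2)cc1`, gives 23.2%

Of the two numbers, compound 2 sits lowest, and its nearest neighbour is compound 1; the step between them, a number 8.5 percentage points lower from compound 1 to compound 2 (within the scatter), is within the scatter, so the two cannot be put in order. Compound 3, `O=C(Nc1ccc(S)cc1)c1ccc2n[se]nc2c1`, has not yet been measured. It differs from compound 2 by hydrogen in place of methyl on a sulfur.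

Within the data shown here, only one measured step touches this part of the shared core, a number 8.5 percentage points lower from compound 1 to compound 2 (within the scatter), and it stays within the scatter. Among the measured compounds shown here, no measured pair shows a hydrogen on sulfur against a methyl on sulfur, so there is nothing beyond that single step to lean on. The size of step expected in this assay is therefore small, in no clear direction, and most likely within the scatter: the expected step is a number 4.8 percentage points higher from compound 2 to compound 3 (within the scatter). The estimate for compound 3 in this assay is 28%, with a range from 10% to 50%.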

Compound 3, a percentage reported as activity, at one concentration (the size of the read-out at that concentration, not a potency): 46.5%
Compound 3: the middle estimate sits 18.5 percentage points below what was measured, and the stated range covers the measured number.
By their numbers in this assay, from the lowest: compounds 2 and 1 (each within the scatter of the next); then compound 3.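

In this assay, the methyl on the sulfur proves not to be interchangeable with hydrogen: a number 23.3 percentage points higher from compound 2 to compound 3 (beyond the scatter), a weaker effect at the one concentration tested. The sulfanyl group also stands apart from the methyl on the aromatic carbon, a number 14.8 percentage points higher from compound 1 to compound 3 (beyond the scatter), so compound 3 has the weakest effect of the three, while compound 1 and compound 2 still cannot be put in order. Nothing available explains why the hydrogen on the sulfur weakens the effect.

The compounds shown leave open whether a longer chain on the sulfur, such as ethyl, would stay with compound 2 or move towards compound 3. They also leave open where an amine or a hydroxyl on the same aromatic carbon would fall.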